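Three Esters at the Assay Limit, a Fourth Expected There

The compounds below may be only part of what the source reports. "The series", "measured", "known", "first", "only" and "open" are said of these compounds alone.

Measured compounds:
- compound 1 `C=C1[C@H](OC(C)=O)[C@@H](OC(=O)C(C)(C)C)[C@@H](OC(C)=O)C(C)(C)/C=C/[C@H](C)[C@H](OC(=O)c2ccccc2)[C@@]2(O)C[C@@](C)(OC(C)=O)[C@H](OC(C)=O)[C@@H]2[C@H]1OCC(C)C`: in a functional assay on NCI/ADR-RES cells (Homo sapiens) for antiproliferative activity, read by MTT assay, with a stated time of 48 h (a higher number here means a weaker inhibitor, a lower number a stronger inhibitor), compound 1 gives > 100000 nM, a limit of the assay and not a number.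
- compound 2 `C=C1[C@H](OC(C)=O)[C@@H](OC(=O)c2cccc(C)c2)[C@@H](OC(C)=O)C(C)(C)/C=C/[C@H](C)[C@H](OC(=O)c2ccccc2)[C@@]2(O)C[C@@](C)(OC(C)=O)[C@H](OC(C)=O)[C@@H]2[C@H]1OCC(C)C`: in this assay compound 2 gives > 100000 nM, again a limit rather than a number.
- compound 3 `C=C1[C@H](OC(C)=O)[C@@H](OC(=O)c2cccc(C)c2)[C@@H](OC(C)=O)C(C)(C)/C=C/[C@H](C)[C@H]2O[C@]3(C)C[C@@]2(OC(=O)c2ccccc2)[C@H]([C@H]3OC(C)=O)[C@H]1OCC(C)C`: in this assay compound 3 gives > 100000 nM, also a limit.

The account concerns three measured esters and one that is still to be tested. Compounds 1 and 2 share a core and differ in one place only: tert-butyl in place of 3-methylphenyl on a carbonyl carbon. The step that this change made, a step that the two limits leave unreadable from compound 2 to compound 1, cannot be read, since both ends sit at the limit; this rests on (the limit of > 100000 nM in this assay, at which 3 of the 3 values shown sit).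

Compound 3 carries a different core; the difference between the two cores is not broken down here. Compound 4 `C=C1[C@H](OC(C)=O)[C@@H](OC(=O)C(C)(C)C)[C@@H](OC(C)=O)C(C)(C)/C=C/[C@H](C)[C@H]2O[C@]3(C)C[C@@]2(OC(=O)c2ccccc2)[C@H]([C@H]3OC(C)=O)[C@H]1OCC(C)C` is built on the core of compound 3 and differs from it by the same change that separates compound 2 from compound 1: tert-butyl in place of 3-methylphenyl on a carbonyl carbon.

For compound 4 the expectation is that a step that the limit leaves unreadable from compound 3 to compound 4 is again a step that cannot be read, with the value remaining at the limit, because compound 3 sits at > 100000 nM and the same change left compound 1 at > 100000 nM. Compound 4 is therefore estimated at 150000 nM, with a range from 50000 nM to 500000 nM, most likely reported only as a limit.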

Compound 4, half-maximal inhibitory concentration: > 100000 nM
Compound 4: no number, only a limit; the forecaster's own chance of this, stated with the estimate: 85%; the middle value is on the limit's open side.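

In this assay compound 4 gives > 100000 nM, a limit of the assay and not a number. No new step can be read from compound 3 to compound 4, since both compounds sit at that limit: the limit of > 100000 nM in this assay, at which 4 of the 4 values shown sit.

The compounds shown leave open whether the core or the ester group has any bearing on the read-out in this assay; none of them gives a number.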